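This account rests on a few compounds, and the source may have more. Where it says the series, first, only, none or still open, it means among the compounds named here.

Measured in a functional assay on A549 cells (Homo sapiens) for cytotoxicity, read by MTT assay, with a stated time of 48 h; a higher number here means a weaker inhibitor, a lower number a stronger inhibitor:
- Compound 1 `COc1ccc(C2=NOC(COc3ccc(-c4nnnn4-c4cc(OC)c(OC)c(OC)c4)cc3N)C2)cc1OC`: 2520 nM
- Compound 2 `COc1ccc(-c2nnnn2-c2cc(OC)c(OC)c(OC)c2)cc1N`: 2630 nM
- Compound 3 `COc1cc(-n2nnnc2-c2ccc(OCC3CC(c4ccc(C(F)(F)F)cc4)=NO3)c(N)c2)cc(OC)c1OC`: 1220 nM

Compound 2, at 2630 nM, lies within the scatter of compound 1, at 2520 nM, while compound 3 gives a clearly lower number, 1220 nM. Compound 4 `COc1cc(-n2nnnc2-c2ccc(OCC3CC(c4ccccc4F)=NO3)c(N)c2)cc(OC)c1OC` comes from compound 2 through one change: a group of 12 heavy atoms (9 carbon, 1 nitrogen, 1 oxygen, 1 fluorine; one five-membered non-aromatic ring with 2 hetero atoms, one six-membered aromatic ring of carbon only) in place of a hydrogen atom, on a saturated chain carbon bound to an oxygen on an aromatic ring.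

Compound 1 and compound 3 also carry a group with a five-membered non-aromatic ring and a six-membered aromatic ring at this place. In compound 1, at 2520 nM, that group leaves the number level with compound 2. The only measured step among these groups is a 2.1-fold lower number from compound 1 to compound 3 (0.32 log units; beyond the scatter), a modest one, with 4-(trifluoromethyl)phenyl in place of 3,4-dimethoxyphenyl. The fluorine-bearing group of compound 4 has not been tested, so the expectation is that its number falls in the range set by compound 1 and compound 3. The expected change in this assay is a 1.5-fold lower number from compound 2 to compound 4 (0.16 log units; within the scatter), small and downward, and probably within the scatter. For compound 4 the estimated value is 1800 nM, with an expected range of 900 nM to 3600 nM.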

Compound 4, half-maximal inhibitory concentration: 1490 nM
For compound 4 the middle estimate is 1.2-fold (0.08 log units) above the measured one; low and high end bracket the measured number.
By their numbers in this assay, from the lowest: compounds 3, 4, 1 and 2 (each within the scatter of the next, the first and the last beyond it).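

In this assay, putting the new group in place of a hydrogen atom on the saturated chain carbon gives a 1.8-fold lower number from compound 2 to compound 4 (0.25 log units; within the scatter) and so does not clearly separate the two compounds, which adds to what compound 1 already showed at this place. With 2-fluorophenyl on the carbon with a double bond to nitrogen, the comparison with 4-(trifluoromethyl)phenyl gives a 1.2-fold higher number from compound 3 to compound 4 (0.09 log units; within the scatter) and the comparison with 3,4-dimethoxyphenyl gives a 1.7-fold lower number from compound 1 to compound 4 (0.23 log units; within the scatter), so compound 4 cannot be told apart from either, even though compound 1 and compound 3 differ beyond the scatter. Still open, on these data alone, is whether an amine or a carboxylic acid in place of the fluorine of compound 4, or a longer chain carrying the same group, would move the number beyond the scatter of compound 2. Nothing available explains why these numbers fall as they do.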